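The source may report more compounds than this note shows. Statements on the series, on what has been measured and on what is new or still open speak of the compounds shown alone.

Among the measured compounds shown here, in a functional assay on MCF7 cells (Homo sapiens) for antiproliferative activity, with a stated time of 96 h (on this read-out higher numbers stand for weaker inhibition and lower numbers for stronger inhibition), compound 1 `Cc1cc(=O)oc2cc(OCC(=O)c3ccccc3C(F)(F)F)ccc12` gives 43200 nM as the only number so far. In this assay compound 2 `COc1cccc(C(=O)COc2ccc3c(C(F)(F)F)cc(=O)oc3c2)c1` stands at "not active" (no number reported) with no number reported. Compound 3 `Cc1ccc(C(=O)COc2ccc3c(C(F)(F)F)cc(=O)oc3c2)cc1` awaits measurement. The structural change is 4-methylphenyl in place of 3-methoxyphenyl on a carbonyl carbon with 4-methylphenyl in place of 3-methoxyphenyl on a carbonyl carbon. For the measured compounds named here, no measured step is available, so only a small step in this assay is expected, towards stronger inhibition if any, with compound 1 at 43200 nM as the sole numerical guide. For compound 3 the estimated value is 40000 nM with an expected range from 12000 nM to 100000 nM on this read-out.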

Compound 3, half-maximal inhibitory concentration: "not active" (no number reported)
Compound 3: no number reported; the estimate stays without a comparison.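

In this assay compound 2 and compound 3 both carry no number, so no step can be read between them. Going by these compounds, how 4-methylphenyl and 3-methoxyphenyl compare on this read-out stays open. No supporting evidence bears on this result.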